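This account rests on a few compounds, and the source may have more. Where it says the series, first, only, none or still open, it means among the compounds named here.

Working notes on the series.

The three measured compounds are compound 1 `CO[C@H]1CC[C@H](NC(=O)c2n[nH]cc2NC(=O)c2c(C)nc3ccccn23)CC1`, compound 2 `COc1cccc(OC)c1C(=O)Nc1c[nH]nc1C(=O)NN1CCOCC1` and compound 3 `COc1ccccc1C(=O)Nc1c[nH]nc1C(=O)N[C@H]1CC[C@H](OC)CC1`. In an ADME assay on MRC5 cells (Homo sapiens) for inhibition, with a stated time of 72 h (a higher number here means that more compound is needed for the effect, a lower number that less compound is needed), compound 1 gives 34000 nM and compound 3 gives 1500 nM. For compound 2 this assay returns only a limit, > 50000 nM, not a number; compound 2 therefore stands at the limit of > 50000 nM in this assay, at which 1 of the 3 values shown sits, the weakest footing on the numbers shown.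

Compound 4 `COc1cccc(OC)c1C(=O)Nc1c[nH]nc1C(=O)NC1CCCCC1` has not been measured. It differs from compound 2 in one place: cyclohexyl in place of morpholin-4-yl on an amide-type nitrogen. Going by the values given here, no step between two measured compounds carries this change, so the direction is taken from the neighbours only: compound 3, with a cyclohexane-based amide and a single methoxy on the benzamide, reaches 1500 nM. For compound 2, the compound with the morpholin-4-yl amide, this assay gives a limit rather than a number. A step downward in this assay, beyond the scatter, is expected for the step of an at least 6.2-fold lower number from compound 2 to compound 4 (0.79 log units; beyond the scatter). Compound 4 is estimated at 8000 nM, with a range from 2000 nM to 40000 nM.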

Compound 4, half-maximal effective concentration: 35000 nM
Compound 4: the middle estimate sits 4.4-fold (0.64 log units) below what was measured; the measured number falls inside the stated range.
By their numbers in this assay, from the lowest: compound 3; then compounds 1 and 4 (each within the scatter of the next). At a limit, above all of these: compound 2.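

The change from morpholin-4-yl to cyclohexyl on the amide-type nitrogen can now be read in this assay, as an at least 1.4-fold lower number from compound 2 to compound 4 (0.15 log units; that floor lies within the scatter). With the rest of the structure unchanged, compound 4 gives a measured number, 35000 nM, so this position can return a value in this assay when it carries a ring of carbon only. The step can be given only as a floor, and its true size stays unknown, because compound 2 returns a limit and not a number: the limit of > 50000 nM in this assay, at which 1 of the 4 values shown sits.

Open, going by these compounds, is how a piperidin-1-yl group or an open butyl chain on the same nitrogen would read with the rest of compound 4 held fixed. Also open, on these data alone, is what each methoxy contributes, since compound 3 and compound 4 differ in more than one place.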